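Two Pyridyl Ethers and One Methylated Analogue

This account rests on a few compounds, and the source may have more. Where it says the series, first, only, none or still open, it means among the compounds named here.

In a physicochemical assay for solubility, read by HPLC, measured as thermodynamic solubility, with a stated time of 4 h, at pH 6.8 (on this read-out lower numbers stand for lower solubility and higher numbers for higher solubility), compound 2 `Cn1c(COc2cccc(C(=O)O)c2)nc2ccc(Oc3ncccc3Cl)cc21` gives 15 ug/mL, the higher of the two numbers recorded so far. Compound 1 `Cc1ccc(Oc2ccc3nc(COc4cccc(C(=O)O)c4)n(C)c3n2)cc1F` gives 5.2 ug/mL in this assay, a gap beyond the usual scatter. Compound 3 `Cc1cc(Cl)cnc1Oc1ccc2nc(COc3cccc(C(=O)O)c3)n(C)c2c1` differs from compound 2 in one place: 5-chloro-3-methylpyridin-2-yl in place of 3-chloropyridin-2-yl on an oxygen on an aromatic ring. Going by the values given here, no measured pair shows this change, so the step cannot be read from the data; a modest decrease in this assay, near the edge of the scatter, is expected, a 1.9-fold lower number from compound 2 to compound 3 (0.27 log units; within the scatter). Compound 3 is therefore estimated at 8 ug/mL, with a range from 3 ug/mL to 20 ug/mL.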

Compound 3, solubility: 3.9 ug/mL
Compound 3: middle estimate off by 2.1-fold (0.31 log units), on the high side, within the range that was stated.
By their numbers in this assay, from the lowest: compounds 3 and 1 (each within the scatter of the next); then compound 2.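

Putting 5-chloro-3-methylpyridin-2-yl in place of 3-chloropyridin-2-yl on an oxygen on an aromatic ring gives, in this assay, a 3.8-fold lower number from compound 2 to compound 3 (0.59 log units; beyond the scatter), so this position does register a change of the group it carries. Nothing available accounts for the step. This single pair also cannot divide it between the added methyl and the new place of the chlorine.

From the compounds shown here alone, whether 5-chloropyridin-2-yl without the methyl would follow compound 3 or compound 2 stays open. So does what an amine on this pyridine ring would give.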